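A Longer Ester Arm on the Shared Core

A few compounds are considered here, and "the series" means these few. Any claim that something is new, unique, unknown or untested is made for them only; others in the source may bear on it.

Among the compounds with values here, compound 3, `COC(=O)C1=C(C)NC(C)=C(C(=O)OCc2ccc(OC)cc2)C1c1cccc([N+](=O)[O-])c1`, stands second highest of the three numbers measured so far in a functional assay on HEK293 cells for antagonist activity at Voltage-dependent L-type calcium channel subunit alpha-1C (Oryctolagus cuniculus), read by FLIPR (a higher number here means a weaker inhibitor, a lower number a stronger inhibitor), giving 51 nM. Compound 1, `C=CCOC(=O)C1=C(C)NC(C)=C(C(=O)OC)C1c1cccc([N+](=O)[O-])c1`, gives 15 nM, and compound 2, `COC(=O)C1=C(C)NC(C)=C(C(=O)OCC(C)[N+](=O)[O-])C1c1cccc([N+](=O)[O-])c1`, gives 108 nM. Within the data shown here, the steps that bear on the ester side of the core are a 3.4-fold higher number from compound 1 to compound 3 (0.53 log units; beyond the scatter) and a 2.1-fold lower number from compound 2 to compound 3 (0.33 log units; beyond the scatter), both modest in size. Compound 4, `COC(=O)C1=C(C)NC(C)=C(C(=O)OCCOCc2ccccc2)C1c1cccc([N+](=O)[O-])c1`, differs from compound 3 by (benzyloxy)methyl in place of 4-methoxyphenyl on a saturated chain carbon bound to an oxygen next to a carbonyl group. Among the measured compounds shown here, no measured step involves (benzyloxy)methyl itself, so the expectation rests on the modest size of the two steps that end at compound 3, which suggest that changes at this chain carbon move the number only modestly. Compound 4 is therefore estimated in this assay at 40 nM, with a range from 15 nM to 120 nM. The expected step is a 1.3-fold lower number from compound 3 to compound 4 (0.11 log units; within the scatter), with no confident direction beyond the scatter.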

Compound 4, half-maximal inhibitory concentration: 9 nM
Estimate against measurement, compound 4: 4.4-fold (0.65 log units) above; measured number outside the range, below it.
By their numbers in this assay, from the lowest: compounds 4 and 1 (each within the scatter of the next); then compound 3; then compound 2.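

At the saturated chain carbon bound to an oxygen next to a carbonyl group, (benzyloxy)methyl shows that this place can carry more than the modest steps seen earlier: in this assay there is a 5.7-fold lower number from compound 3 to compound 4 (0.75 log units; beyond the scatter) and a 12-fold lower number from compound 2 to compound 4 (1.08 log units; beyond the scatter), the latter large. The groups exchanged between compound 3 and compound 4 hold the same six-membered aromatic ring and the same count of hydrogen-bond acceptors, so these counts do not separate the two compounds. Against the vinyl of compound 1, the longer arm gives a 1.7-fold lower number from compound 1 to compound 4 (0.22 log units; within the scatter), which lies within the scatter, so the two compounds cannot be ordered.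

The compounds shown leave open whether the ether oxygen or the length of the chain goes with the lower number, and how an amine on the same arm would read. Nothing measured here accounts for the size of these steps.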